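Pyridin-4-yl in place of thiophen-3-yl: compound 4

A few compounds are considered here, and "the series" means these few. Any claim that something is new, unique, unknown or untested is made for them only; others in the source may bear on it.

Three compounds of the series carry numbers in a functional assay on Huh-7 cells (Homo sapiens) for inhibition, read by sulforhodamine B assay, with a stated time of 72 h; a lower number here means a stronger inhibitor, a higher number a weaker inhibitor. Compound 1 `COc1cc(OC)c(C(=O)/C=C/c2cn(-c3ccccc3)nc2-c2ccsc2)c(OC)c1` gives 6100 nM, the highest of the three. Compound 2 `COc1ccc(C(=O)/C=C/c2cn(-c3ccccc3)nc2-c2ccsc2)c(OC)c1OC` gives 4200 nM, and compound 3 `COc1ccc(C(=O)/C=C/c2cn(-c3ccccc3)nc2-c2ccsc2)c(OC)c1` gives 3000 nM. Compound 1 stands nearest to compound 2, within the scatter, and furthest from compound 3, with a 2.0-fold lower number from compound 1 to compound 3 (0.31 log units; beyond the scatter). The other measured step, a 1.4-fold lower number from compound 2 to compound 3 (0.15 log units; within the scatter), stays within the scatter. Both of these steps put hydrogen in place of methoxy on an aromatic carbon and leave the rest of the shared core unchanged.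

Compound 4 `COc1cc(OC)c(C(=O)/C=C/c2cn(-c3ccccc3)nc2-c2ccncc2)c(OC)c1` differs from compound 1 elsewhere: pyridin-4-yl in place of thiophen-3-yl on an aromatic carbon. Among the compounds with values here, no measured step touches this position, so the series itself gives no direction and no size for the change. Within the data shown here, the working expectation for compound 4 is therefore a step no larger than the scatter, a 1.0-fold lower number from compound 1 to compound 4 (0.01 log units; within the scatter), carried with a wide range because no precedent exists. Compound 4 is estimated at 6000 nM, expected to fall between 2500 nM and 15000 nM.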

Compound 4, half-maximal inhibitory concentration: 2600 nM
The estimate for compound 4 lay 2.3-fold (0.36 log units) above the measured number; the range from low to high includes it.
By their numbers in this assay, from the lowest: compounds 4, 3, 2 and 1 (each within the scatter of the next, the first and the last beyond it).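

This position, on an aromatic carbon of a five-membered aromatic ring with 2 nitrogen, now has its first reading: in this assay, pyridin-4-yl in place of thiophen-3-yl gives a 2.3-fold lower number from compound 1 to compound 4 (0.37 log units; beyond the scatter), a modest step beyond the scatter. The position thus accepts a six-membered aromatic ring where a five-membered one stood, with no rise in the number. The change alters ring size and the hetero atom together, and this single step cannot separate the two, while nothing available explains the direction of the step.

Going by these compounds, whether the same step holds with the methoxy patterns of compound 2 and compound 3 remains open. Also open, on these data alone, is how this position responds to pyridin-3-yl, to an unsubstituted phenyl, or to a ring carrying an amine or a carboxylic acid.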